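Isobutoxy in place of cyclohexylmethoxy: compound 3 in prospect

The compounds below may be only part of what the source reports. "The series", "measured", "known", "first", "only" and "open" are said of these compounds alone.

In a functional assay on NCI-H23 cells (Homo sapiens) for antiproliferative activity, read by sulforhodamine B assay (on this read-out lower numbers stand for stronger inhibition of growth and higher numbers for weaker inhibition of growth), compound 2 `O=C(/C=C/c1ccc(O)cc1)c1c(O)cccc1OCC1CCCCC1` gives > 30000 nM, which is a limit of the assay and not a number. Compound 1 `CC(C)(C)CCOc1cccc(O)c1C(=O)/C=C/c1ccc(O)cc1` gives 3130 nM in this assay. Among the measured compounds shown here, the one measured step that bears on the change is an at least 9.5-fold higher number from compound 1 to compound 2 (0.98 log units; beyond the scatter), with cyclohexyl in place of neopentyl. Going by these compounds, it lies beyond the scatter, but one end of it is a limit, so its full size stays open.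

Compound 3 `CC(C)COc1cccc(O)c1C(=O)/C=C/c1ccc(O)cc1` differs from compound 2 by isopropyl in place of cyclohexyl on a saturated chain carbon bound to an oxygen on an aromatic ring. Isopropyl has no measured precedent here, so the expectation rests on that single step, read in reverse: a move to lower numbers of comparable size, towards stronger inhibition of growth. The expected step is an at least 6.0-fold lower number from compound 2 to compound 3 (0.77 log units; beyond the scatter). The estimate for compound 3 is 5000 nM, with an expected range of 1200 nM to 25000 nM.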

Compound 3, concentration for 50% growth inhibition: 3220 nM
Compound 3: middle estimate off by 1.6-fold (0.19 log units), on the high side, within the range that was stated.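

Isopropyl in place of cyclohexyl on a saturated chain carbon bound to an oxygen on an aromatic ring gives an at least 9.3-fold lower number from compound 2 to compound 3 (0.96 log units; beyond the scatter) in this assay, so compound 2 now stands apart from two compounds with open-chain groups at this position. Compound 2 carries a limit of the assay and not a number, so the full size of that step stays open: the limit of > 30000 nM in this assay, at which 1 of the 3 values shown sits.

Isopropyl in place of neopentyl gives a 1.0-fold higher number from compound 1 to compound 3 (0.01 log units; within the scatter) and so does not separate these two open-chain groups in this assay.

Going by these compounds, whether cyclopropyl or cyclopentyl at this position would read like compound 2 or like compound 3 stays open. Also open, on these data alone, is what an amine, a carboxylic acid or a longer straight chain would give here.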